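The source may hold more compounds than are shown below. What is called first, only, known or untested is meant among the compounds shown, and "the series" means these compounds.

The measured compounds, in order of their numbers:

Compound 1 `CCN1CCN(c2c(C(C)=O)c(=O)oc3cc(Nc4ncc(F)c(-c5ccc(F)cc5OC)n4)ccc23)CC1` gives 550 nM in a functional assay on MV4-11 cells (Homo sapiens) for inhibition, read by luminescence and CellTiter-Glo, with a stated time of 72 h; on this read-out higher numbers stand for weaker inhibition and lower numbers for stronger inhibition.
Compound 2 `CCN1CCN(c2c(C(C)=O)c(=O)oc3cc(Nc4nccc(-c5ccc(F)cc5OC)n4)ccc23)CC1` gives 740 nM in this assay.
Compound 3 `COc1ccccc1-c1ccnc(Nc2ccc3c(N4CCCNCC4)cc(=O)oc3c2)n1` gives 1680 nM in this assay.

Compound 2 stands second highest of the three numbers. Its nearest neighbour is compound 1, and the change a 1.3-fold higher number from compound 1 to compound 2 (0.13 log units; within the scatter) lies within the scatter. For the measured compounds named here, compound 3 lies furthest off, with a higher number than compound 2 that is beyond the scatter, but these two compounds differ in several places, so their pair gives no single step.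

Compound 4 `COc1cc(F)ccc1-c1ccnc(Nc2ccc3c(N4CCN(C)CC4)c(C(C)=O)c(=O)oc3c2)n1` differs from compound 2 in one place: hydrogen in place of methyl on a saturated chain carbon bound to an amine nitrogen in a ring. Going by the values given here, none of the measured steps touches this position; the only step of one change, from compound 1 to compound 2, concerns a fluoro on an aromatic carbon and gives no guide here. The change itself is a small one on the chain bound to the ring amine nitrogen, and the shared core and the rest of compound 2 are kept. Compound 4 is therefore expected to give a number close to that of compound 2, with a 1.1-fold lower number from compound 2 to compound 4 (0.02 log units; within the scatter) as the expected step in this assay. The estimate for compound 4 is 700 nM, with a range from 300 nM to 1600 nM.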

Compound 4, half-maximal inhibitory concentration: 520 nM
Estimate against measurement, compound 4: 1.3-fold (0.13 log units) above; the range from low to high includes it.
By their numbers in this assay, from the lowest: compounds 4, 1 and 2 (each within the scatter of the next); then compound 3.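

Swapping 4-ethylpiperazin-1-yl for 4-methylpiperazin-1-yl gives the first reading at this position: a 1.4-fold lower number from compound 2 to compound 4 (0.15 log units; within the scatter) in this assay, so compound 2 and compound 4 cannot be told apart. On the amine nitrogen in the ring, ethyl and methyl therefore read alike in this series, a result that the fluoro step had not addressed. No measurement shown bears on why the two compounds read alike.

Only ethyl and methyl are shown on this nitrogen, so it remains open whether a bare amine hydrogen, a longer chain such as butyl, or a chain ending in a carboxylic acid would read alike. On these data alone, it also remains open whether the same change would read alike with the aromatic fluoro of compound 1 in place.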